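The source may report more compounds than this note shows. Statements on the series, on what has been measured and on what is new or still open speak of the compounds shown alone.

In a functional assay on FM3A cells (Mus musculus) for antiproliferative activity, read by cell counting, with a stated time of 2 days (a lower number here means a stronger inhibitor, a higher number a weaker inhibitor), compound 1, `COc1ccc(Nc2nc(N)c(C(=O)c3ccc(OC)c(OC)c3)s2)cc1`, gives 71 nM. Compound 3, `COc1ccc(Nc2nc(N)c(C(=O)c3cc(OC)c(OC)c(OC)c3)s2)cc1`, differs from compound 1 by methoxy in place of hydrogen on an aromatic carbon. Compound 3 gives 2200 nM, so that the change produced a 31-fold higher number from compound 1 to compound 3 (1.49 log units; beyond the scatter). Compound 2, `COc1ccccc1C(=O)c1sc(Nc2ccccc2)nc1N`, gives 1100 nM in this assay; its number is higher than that of compound 1 and within the scatter of that of compound 3. The difference between the core of compound 2 and the core of compound 1 is not broken down here.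

Compound 4, `COc1ccc(Nc2nc(N)c(C(=O)c3ccccc3OC)s2)cc1`, has not yet been measured. It differs from compound 2 by methoxy in place of hydrogen on an aromatic carbon. Among the compounds with values here, this is the same kind of change as the one from compound 1 to compound 3, not the same: there the entering methoxy sat ortho to a methoxy group, meta to a large group and meta to a methoxy group, whereas here it sits para to a large group. Because the earlier step, a 31-fold higher number from compound 1 to compound 3 (1.49 log units; beyond the scatter), arose at a differently surrounded place, it is not taken as a guide to the size of the new step. The expectation for compound 4 instead rests on compound 1, which carries the same entering group at the same kind of place and gives 71 nM, against compound 2 with 1100 nM. The step from compound 2 to compound 4 is estimated at a 2.2-fold lower number from compound 2 to compound 4 (0.34 log units; beyond the scatter). In this assay compound 4 is expected to give 500 nM, within a range from 150 nM to 2000 nM.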

Compound 4, half-maximal inhibitory concentration: 52 nM
Beside the measured number, compound 4's estimate is 9.6-fold (0.98 log units) above it; the whole stated range lies above it.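

The change from phenyl to 4-methoxyphenyl produced a 21-fold lower number from compound 2 to compound 4 (1.33 log units; beyond the scatter) in this assay, so on this core a methoxy in place of hydrogen on an aromatic carbon brings a large gain in potency. Set beside the earlier step, the same kind of change does not carry over from one core to another in this series, neither in size nor in direction: the same change on two cores in this assay, a 31-fold higher number (1.49 log units; beyond the scatter) from compound 1 to compound 3 and a 21-fold lower number (1.33 log units; beyond the scatter) from compound 2 to compound 4, 660-fold (2.82 log units) apart, beyond the scatter of two such steps The two steps differ both in the core and in the surroundings of the carbon that takes the methoxy, which here sits para to a large group, so the comparison does not show which of these accounts for the gap, and two steps give no rule for any further core.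

The compounds shown leave open whether the gain at this place belongs to methoxy itself or would also appear with another group there, such as an ethoxy group, a fluorine atom or an amine. They also leave open how the change from phenyl to 4-methoxyphenyl behaves on cores with other arrangements of methoxy groups on the aromatic ring attached to the carbonyl.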